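The compounds below may be only part of what the source reports. "The series", "measured", "known", "first", "only" and "open" are said of these compounds alone.

In a functional assay on RS4-11 cells (Homo sapiens) for inhibition, read by CCK-8 assay, with a stated time of 48 h (a higher number here means a weaker inhibitor, a lower number a stronger inhibitor), compound 1 `COc1ccc(NC(=S)NCCNS(=O)(=O)c2sccc2-c2ccc(C)cc2Oc2ccc(O)c(O)c2)cc1` gives 8300 nM and compound 2 `O=C(NCCNS(=O)(=O)c1ccc(-c2ccccc2O[C@H]2CC[C@H](O)CC2)s1)Nc1cc(Cl)cc(Cl)c1` gives 14100 nM. These two numbers lie within the usual scatter of each other, so compound 1 cannot be ranked against compound 2, and both sit in the same broad range. Compound 3 `Cc1ccc(-c2ccsc2S(=O)(=O)NCCNC(=O)Nc2cc(Cl)cc(Cl)c2)c(Oc2ccc(O)c(O)c2)c1` keeps the core of compound 1 and changes one group on an amine nitrogen: a group of 11 heavy atoms (7 carbon, 1 nitrogen, 1 oxygen, 2 chlorine; one six-membered aromatic ring of carbon only) in place of a group of 11 heavy atoms (8 carbon, 1 nitrogen, 1 oxygen, 1 sulfur; one six-membered aromatic ring of carbon only), on an amine nitrogen. The entering (3,5-dichlorophenyl)carbamoyl group is also present in compound 2, which gives 14100 nM on a different core. For the measured compounds named here, no measured pair shows this change alone, so the evidence for its effect is thin, and no shift beyond the scatter is expected. The expected step is a 1.2-fold lower number from compound 1 to compound 3 (0.07 log units; within the scatter). For compound 3 the estimated value is 7000 nM, with an expected range of 2500 nM to 20000 nM.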

Compound 3, half-maximal inhibitory concentration: 5100 nM
Compound 3: the middle estimate sits 1.4-fold (0.14 log units) above what was measured; the measured number falls inside the stated range.
By their numbers in this assay, from the lowest: compounds 3, 1 and 2 (each within the scatter of the next, the first and the last beyond it).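

On the amine nitrogen of the shared core, the (3,5-dichlorophenyl)carbamoyl group replaces the group in compound 1 with a 1.6-fold lower number from compound 1 to compound 3 (0.21 log units; within the scatter) in this assay. For the compounds shown here, this pair is the first here to differ in one place, and it shows that this exchange, between two groups of 11 heavy atoms that each hold one six-membered aromatic ring of carbon only, does not move the number beyond the scatter. No measurement on these compounds offers an explanation for this result.

The two groups differ in more than one feature, so this single pair cannot separate the contribution of each feature. It also leaves open whether a carboxylic acid, an amine or a longer chain on this nitrogen would shift the number beyond the scatter.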